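Solubility notes: phenyl in place of the substituted piperidine

The source may report more compounds than this note shows. Statements on the series, on what has been measured and on what is new or still open speak of the compounds shown alone.

Measured in a physicochemical assay for solubility, in phosphate buffer, at pH 7.4; a higher number here means a more soluble compound, a lower number a less soluble compound:
- compound 1 `COCC1CCN(c2nccnc2OC2CN(c3ccc4ccccc4n3)C2)CC1` gives 53000 nM
- compound 2 `CN(C)C1CCN(c2nccnc2OC2CN(c3ccc4ccccc4n3)C2)CC1` gives 500000 nM

Compound 2 holds the higher of the two numbers. Among the measured compounds shown here, the only measured step is a 9.4-fold higher number from compound 1 to compound 2 (0.97 log units; beyond the scatter) and it comes with dimethylamino in place of methoxymethyl on a saturated ring carbon.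

Compound 3 `c1ccc(-c2nccnc2OC2CN(c3ccc4ccccc4n3)C2)cc1` has not yet been measured. It carries phenyl in place of 4-(dimethylamino)piperidin-1-yl on an aromatic carbon. The measured step bears on this change only in part. Compound 1 lacks dimethylamino but keeps the saturated ring, whereas compound 3 lacks both. For the measured compounds named here, no measured compound carries phenyl, so the size of the change is poorly constrained and the range is kept wide.

A drop in this assay is expected, and one larger than the measured step, with the expected size being a 63-fold lower number from compound 2 to compound 3 (1.80 log units; beyond the scatter) and no more than a rough guide. Compound 3 is estimated at 8000 nM (expected range 1000 nM to 60000 nM).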

Compound 3, solubility: < 1000 nM
Compound 3: a limit, no number; the forecaster's own chance of this, stated with the estimate: 10%; middle value at least 8.0-fold (0.90 log units) from the limit.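

On an aromatic carbon of the ring with two nitrogens, the change from a substituted piperidine to phenyl outweighs the change made on the piperidine itself in this assay: the step is an at least 500-fold lower number from compound 2 to compound 3 (2.69 log units; beyond the scatter), whereas the earlier one was a 9.4-fold higher number from compound 1 to compound 2 (0.97 log units; beyond the scatter). The fall does not depend on the dimethylamino group alone, since the piperidine of compound 1, which carries methoxymethyl instead, gives an at least 53-fold lower number from compound 1 to compound 3 (1.72 log units; beyond the scatter). The reading for compound 3 is a limit of the assay and not a number: the limit of < 1000 nM in this assay, at which 1 of the 3 values shown sits.

From the compounds shown here alone, how far compound 3 lies under that limit stays open, and with it the full size of both steps. Also open, going by these compounds, is whether the fall follows from losing the saturated ring or from the aromatic ring that enters, as only a cyclohexyl or a pyridyl group in this place could separate the two.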